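The source may hold more compounds than are shown below. What is called first, only, known or untested is meant among the compounds shown, and "the series" means these compounds.

Compound 2, `CC(=O)c1cc2ccc(OCCCCCn3cc(CNC(=O)CCCCC4CCSS4)nn3)cc2oc1=O`, is the weaker of the two measured compounds in a functional assay on PC-12 cells (Rattus norvegicus) for cytotoxicity, read by MTT assay, with stated times of 3 h and 2 h, tested at 20 uM; on this read-out lower numbers stand for a weaker effect and higher numbers for a stronger effect at the one concentration tested: compound 2 gives 20.7%, the lowest of the two numbers, while compound 1, `O=C(CCCCC1CCSS1)NCc1cn(CCCCCOc2ccc3ccc(=O)oc3c2)nn1`, gives 78.5% in this assay. For the measured compounds named here, the one measured step, a number 57.8 percentage points lower from compound 1 to compound 2 (beyond the scatter), separates them, and it is the only step available. Compound 3, `CCOC(=O)c1cc2ccc(OCCCCCn3cc(CNC(=O)CCCCC4CCSS4)nn3)cc2oc1=O`, differs from compound 2 by ethoxy in place of methyl on a carbonyl carbon, which cut one bond further out reads acetyl to ethoxycarbonyl. Going by the values given here, no measured step follows this change: the step from compound 1 to compound 2 concerns the presence of the acetyl on the aromatic carbon, not a swap within the carbonyl group, so it bears on compound 3 only in that both compound 2 and compound 3 carry a carbonyl at that place. On this basis a step within the scatter, or at most a small one, is expected from compound 2 to compound 3, a number 4.3 percentage points higher from compound 2 to compound 3 (within the scatter), in this assay. Compound 3 is therefore estimated at 25%, within a range of 8% to 50%, in this assay.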

Compound 3, a percentage reported as activity, at one concentration (the size of the read-out at that concentration, not a potency): 39.5%
For compound 3 the middle estimate is 14.5 percentage points below the measured one; the range from low to high includes it.
By their numbers in this assay, from the lowest: compound 2; then compound 3; then compound 1.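

In this assay, the identity of the group on this carbonyl carbon matters, not just the presence of a carbonyl at that place: ethoxy in place of methyl gives a number 18.8 percentage points higher from compound 2 to compound 3 (beyond the scatter). The ethoxycarbonyl group recovers only part of the drop seen with acetyl, since replacing hydrogen on the aromatic carbon with ethoxycarbonyl still gives a number 39 percentage points lower from compound 1 to compound 3 (beyond the scatter), so among these three compounds, the one carrying hydrogen there keeps the highest number. Nothing available explains why the two carbonyl groups differ in this way.

The compounds shown do not separate the contribution of the oxygen in ethoxy from that of its two carbons, a question that a methoxy group or an ethyl group on the same carbonyl carbon would address. They also leave open whether an amine or a hydroxyl group on that carbonyl carbon, the latter giving a carboxylic acid, would bring the number closer to that of compound 2 or to that of compound 1.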